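Aryl replacement at the core of compound 1

The source may report more compounds than this note shows. Statements on the series, on what has been measured and on what is new or still open speak of the compounds shown alone.

Compound 1 `Cc1nc2c3ccccc3ccc2c2nc3c(ccc4ccccc43)c(-c3nccnc3N)c12` is the reference point of this small series. For the measured compounds named here, in a functional assay on AGS cells (Homo sapiens) for cytotoxicity, read by MTT assay, with a stated time of 48 h (a higher number here means a weaker inhibitor, a lower number a stronger inhibitor), compound 1 gives 2260 nM, the lowest number of the three measured so far. Compound 2 `Cc1nc2c3ccccc3ccc2c2nc3c(ccc4ccccc43)c(-c3cccc4ccccc34)c12` gives 12100 nM and compound 3 `Cc1nc2c3ccccc3ccc2c2nc3c(ccc4ccccc43)c(-c3ccccc3N)c12` gives 12100 nM; the step of no change at the digits printed from compound 2 to compound 3 (within the scatter) shows these two lie together, while a 5.4-fold higher number from compound 1 to compound 2 (0.73 log units; beyond the scatter) and a 5.4-fold higher number from compound 1 to compound 3 (0.73 log units; beyond the scatter) show that exchanging the 3-aminopyrazin-2-yl group for either a naphthalen-1-yl or a 2-aminophenyl group raised the number by the same amount.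

Compound 4 `Cc1nc2c3ccccc3ccc2c2nc3c(ccc4ccccc43)c(-c3cc(O)nc4ccccc34)c12` makes a change of the same kind at the same aromatic carbon: 2-hydroxyquinolin-4-yl in place of 3-aminopyrazin-2-yl on an aromatic carbon. Both steps from compound 1 bear on it, each carrying a modest rise, and the entering group shares its two fused six-membered aromatic rings with the naphthalen-1-yl of compound 2 while keeping a hydrogen-bond donor. A rise in the number of similar size is therefore expected, with some uncertainty in either direction, so for compound 4 the expected step is a 3.5-fold higher number from compound 1 to compound 4 (0.55 log units; beyond the scatter). The estimate for compound 4 in this assay is 8000 nM, within a range from 2500 nM to 25000 nM.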

Compound 4, half-maximal inhibitory concentration: 15800 nM
For compound 4 the middle estimate is 2.0-fold (0.30 log units) below the measured one; measured number inside the range.
By their numbers in this assay, from the lowest: compound 1; then compounds 2, 3 and 4 (each within the scatter of the next).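

In this assay the move to 2-hydroxyquinolin-4-yl gives a 7.0-fold higher number from compound 1 to compound 4 (0.84 log units; beyond the scatter) and so leaves compound 1 apart from all three replacements at this aromatic carbon. The replacements now form one group, with a 1.3-fold higher number from compound 3 to compound 4 (0.12 log units; within the scatter) and a 1.3-fold higher number from compound 2 to compound 4 (0.12 log units; within the scatter) showing no separation among them. Compound 4 also shows that an entering group with a ring nitrogen and a hydrogen-bond donor does not by that alone bring the number back to that of compound 1. Nothing available accounts for the separation of compound 1 from the other three.

Going by these compounds, whether the number of compound 1 depends on the amine or on the ring nitrogens of 3-aminopyrazin-2-yl remains open. A plain pyrazin-2-yl and a 3-aminopyridin-2-yl at the same carbon would separate these two parts of the group.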